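This account rests on a few compounds, and the source may have more. Where it says the series, first, only, none or still open, it means among the compounds named here.

Measured compounds:
Compound 1 `Cn1c(=O)c(=O)n(C2CCCC2)c2nc(N/N=C/c3ccc(S(C)(=O)=O)cc3)ncc21` — 86600 nM
Compound 2 `Cn1c(=O)c(=O)n(C2CCCC2)c2nc(N/N=C/c3cccc(Cl)c3Cl)ncc21` — 26400 nM
Compound 3 `COc1ccc(/C=N/Nc2ncc3c(n2)n(C2CCCC2)c(=O)c(=O)n3C)cc1` — 36100 nM

In a functional assay on HCT-116 cells (Homo sapiens) for antiproliferative activity, read by MTT assay (on this read-out higher numbers stand for weaker inhibition and lower numbers for stronger inhibition), compound 1 gives the highest of the three numbers. Its nearest neighbour is compound 3, and the step of a 2.4-fold lower number from compound 1 to compound 3 (0.38 log units; beyond the scatter) is modest; the step of a 3.3-fold lower number from compound 1 to compound 2 (0.52 log units; beyond the scatter) is larger but still modest, and compounds 2 and 3 lie within the scatter of each other, as a 1.4-fold higher number from compound 2 to compound 3 (0.14 log units; within the scatter) shows.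

Compound 4 `Cn1c(=O)c(=O)n(C2CCCC2)c2nc(N/N=C/c3cccc(O)c3)ncc21` has not yet been measured. It differs from compound 1 in one place: 3-hydroxyphenyl in place of 4-(methylsulfonyl)phenyl on a carbon with a double bond to nitrogen. Both measured steps from compound 1 bear on this change, since each also removes the 4-(methylsulfonyl)phenyl group, and each gave a modestly lower number. The expectation for compound 4 in this assay is therefore a modest lowering of the same order, a 2.5-fold lower number from compound 1 to compound 4 (0.39 log units; beyond the scatter). On that basis compound 4 is estimated at 35000 nM, with a plausible range from 15000 nM to 80000 nM.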

Compound 4, half-maximal inhibitory concentration: 37200 nM
Compound 4: the middle estimate sits 1.1-fold (0.03 log units) below what was measured; the range from low to high includes it.
By their numbers in this assay, from the lowest: compounds 2, 3 and 4 (each within the scatter of the next); then compound 1.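

In this assay, a third replacement of 4-(methylsulfonyl)phenyl at this place, a carbon with a double bond to nitrogen, again gives a modest shift, a 2.3-fold lower number from compound 1 to compound 4 (0.37 log units; beyond the scatter), now with a group that carries a hydrogen-bond donor. The other two replacements cannot be told apart from it, with a 1.0-fold higher number from compound 3 to compound 4 (0.01 log units; within the scatter) and a 1.4-fold higher number from compound 2 to compound 4 (0.15 log units; within the scatter), so among these four compounds 3-hydroxyphenyl, 4-methoxyphenyl and 2,3-dichlorophenyl read alike and only compound 1 stands apart, as the weakest. Nothing measured here gives a reason for this.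

The compounds shown leave open whether a phenyl group bearing an amine or a carboxylic acid would read with these three or with compound 1. They also leave open whether a longer chain in place of the phenyl ring would move the number beyond this shared level.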